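Diaryl urea series: dropping one trifluoromethyl group

The compounds below may be only part of what the source reports. "The series", "measured", "known", "first", "only" and "open" are said of these compounds alone.

Compound 2 `COc1cc(Cl)cc(-c2nn(-c3cccc(NC(=O)Nc4cc(C(F)(F)F)cc(C(F)(F)F)c4)c3)cc2-c2ccncc2)c1` holds the highest of the two numbers measured in a functional assay on IGROV-1 cells (Homo sapiens) for inhibition, read by sulforhodamine B assay, with a stated time of 48 h, tested at 0.01 uM (a lower number here means a stronger effect, a higher number a weaker effect of the compound at the concentration tested), where compound 2 gives 103%. For the measured compounds named here, the nearest is compound 1 `O=C(Nc1cccc(-n2cc(-c3ccncc3)c(-c3cc(O)cc(Cl)c3)n2)c1)Nc1ccc(Cl)c(C(F)(F)F)c1`; in this assay compound 1 gives 94%, a value within the scatter of the one for compound 2, so no order between the two is claimed. Both read-outs sit near full activity at the concentration tested. Compound 3 `COc1cc(Cl)cc(-c2nn(-c3cccc(NC(=O)Nc4cccc(C(F)(F)F)c4)c3)cc2-c2ccncc2)c1` is not yet measured. Its difference from compound 2 is hydrogen in place of trifluoromethyl on an aromatic carbon. Going by the values given here, no step between measured compounds is at hand to size such a change, and the two measured values show nothing beyond the scatter. The expected step is a number 3 percentage points lower from compound 2 to compound 3 (within the scatter), none beyond the scatter. Compound 3 is expected to give 100% in this assay, with a range from 88% to 110%.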

Compound 3, a percentage reported as activity, at one concentration (the size of the read-out at that concentration, not a potency): 106%
For compound 3 the middle estimate is 6 percentage points below the measured one; the measured number falls inside the stated range.
By their numbers in this assay, from the lowest: compounds 1, 2 and 3 (each within the scatter of the next, the first and the last beyond it).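

In this assay, for the compounds shown here, hydrogen in place of trifluoromethyl gives the first sized step at this aromatic carbon: a number 3 percentage points higher from compound 2 to compound 3 (within the scatter). At this position, meta to a trifluoromethyl group, one of the two trifluoromethyl groups can thus be exchanged for hydrogen without a difference beyond the scatter, though this holds only for the single low concentration tested, where the read-outs sit near full activity. Nothing at hand speaks to why the step has this size.

Open, as far as these compounds go, is whether another group on this carbon, such as a nitrile, an amine or a carboxylic acid, would give a read-out beyond the scatter. Also open, from the compounds shown here alone, is whether the remaining trifluoromethyl group can be exchanged in the same way, and whether this step holds at concentrations where the read-out lies well below full activity.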